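Three hydrazone thiazoles and a methyl addition

This account rests on a few compounds, and the source may have more. Where it says the series, first, only, none or still open, it means among the compounds named here.

Compound 1 `Fc1ccc(-c2csc(N/N=C/c3cccs3)n2)cc1`: 94.6%
Compound 2 `Clc1ccc(/C=N/Nc2nc(-c3ccccc3)cs2)c(Cl)c1`: 92.8%
Compound 3 `COC(=O)c1cc(-c2csc(N/N=C/c3cccs3)n2)ccc1OCc1ccccc1`: 95.5%

All three were tested in a functional assay, read by spectrophotometry, with a stated time of 15 min, tested at 60 ug/mL; a lower number here means a weaker effect, a higher number a stronger effect of the compound at the concentration tested. The value of compound 2 lies within the scatter of compound 1 and within the scatter of compound 3, so the three numbers cannot be told apart; each sits near full inhibition.

Compound 4 `Cc1ccc(-c2csc(N/N=C/c3ccc(Cl)cc3Cl)n2)cc1` is yet to be measured. It differs from compound 2 by methyl in place of hydrogen on an aromatic carbon. For the measured compounds named here, no measured pair shows this change, so its effect is unknown. Because compound 2 gives 92.8% and thus already sits close to the top of the scale, the step of a number 0.8 percentage points lower from compound 2 to compound 4 (within the scatter) is expected to stay within the scatter, in no particular direction. For compound 4 an inhibition of 92% is expected, between 82% and 98%.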

Compound 4, a percentage reported as inhibition, at one concentration (the size of the read-out at that concentration, not a potency): 93.3%
For compound 4 the middle estimate is 1.3 percentage points below the measured one; measured number inside the range.
By their numbers in this assay, from the lowest: compounds 2, 4, 1 and 3 (each within the scatter of the next).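

For the compounds shown here, this is the first pair here that differs in one place: in this assay, methyl in place of hydrogen on the aromatic carbon para to a large group gives a number 0.5 percentage points higher from compound 2 to compound 4 (within the scatter) and so phenyl and 4-methylphenyl cannot be told apart. Both compounds sit near full inhibition, where a real difference would be hard to see. No measurement offered here gives a reason for this result. Going by these compounds, whether an amine, a carboxylic acid or a longer chain at this position would keep the inhibition stays open.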